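This account rests on a few compounds, and the source may have more. Where it says the series, first, only, none or still open, it means among the compounds named here.

Measured so far:
compound 1 `CC(C)(C)OC(=O)CCCC[N+]1(C)CCc2c(sc(NC(=O)Nc3ccc(Cl)cc3)c2C(N)=O)C1` — 140 nM
compound 2 `CCN1CCc2c(sc(NC(=O)Nc3ccc(Cl)cc3)c2C(=O)NC)C1` — > 25000 nM

For the measured compounds named here, compound 1 is the only compound with a number in a functional assay (strain AB) with Danio rerio as the target, read by microscopy, with a stated time of 1 h; a lower number here means that less compound is needed, a higher number that more compound is needed for the effect; compound 1 gives 140 nM. For compound 2 this assay reports only a limit, (the limit of > 25000 nM in this assay, at which 1 of the 2 values shown sits). Compound 3 `C[N+]1(CC2CC2)CCc2c(sc(NC(=O)Nc3ccc(Cl)cc3)c2C(N)=O)C1` is not yet measured. It differs from compound 1 by cyclopropyl in place of 3-(tert-butoxycarbonyl)propyl on a saturated chain carbon bound to an amine nitrogen in a ring. Going by the values given here, no measured pair isolates this change, so the size of the step is uncertain. The estimate for compound 3 is a step of a 2.1-fold higher number from compound 1 to compound 3 (0.33 log units; beyond the scatter), barely beyond the scatter. Compound 3 is expected to give about 300 nM, between 60 nM and 1500 nM.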

Compound 3, half-maximal effective concentration: 360 nM
Compound 3: the middle estimate sits 1.2-fold (0.08 log units) below what was measured; measured number inside the range.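

In this assay, the position on a saturated chain carbon bound to an amine nitrogen in a ring accepts a much smaller group: cyclopropyl in place of 3-(tert-butoxycarbonyl)propyl gives a 2.6-fold higher number from compound 1 to compound 3 (0.41 log units; beyond the scatter). The step is modest, so the tert-butoxycarbonyl group is not needed for compound 3 to give 360 nM. No measured property shown accounts for the step.

For the compounds shown here, no measured pair treats the ester, the chain and the cyclopropyl ring apart. A plain butyl chain or a carboxylic acid at the chain end would separate these.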